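The source may hold more compounds than are shown below. What is called first, only, known or untested is meant among the compounds shown, and "the series" means these compounds.

Three measured compounds share one core and differ only in the aryl group on the amide nitrogen. Compound 1 `O=C(CSc1nc(Nc2ccccc2)c2ccccc2n1)Nc1ccccc1F` gives 12400 nM in a functional assay on PC-3 cells (Homo sapiens) for inhibition, read by MTT assay, with a stated time of 72 h; a lower number here means a stronger inhibitor, a higher number a weaker inhibitor. Compound 2 `O=C(CSc1nc(Nc2ccccc2)c2ccccc2n1)Nc1ccccc1Cl` gives 14600 nM in this assay, and compound 3 `O=C(CSc1nc(Nc2ccccc2)c2ccccc2n1)Nc1ccc(Cl)c(Cl)c1` gives 12100 nM there. Compound 2 and compound 3 differ by 3,4-dichlorophenyl in place of 2-chlorophenyl on an amide-type nitrogen, and their two values lie within the scatter of each other. Between compound 2 and compound 1 the change is fluoro in place of chloro on an aromatic carbon, and it produced a 1.2-fold lower number from compound 2 to compound 1 (0.07 log units; within the scatter).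

Compound 4 `O=C(CSc1nc(Nc2ccccc2)c2ccccc2n1)Nc1ccc(F)c(Cl)c1` has not yet been measured in this assay. It arises from compound 3 by fluoro in place of chloro on an aromatic carbon. This is the same kind of change as that from compound 2 to compound 1, not the same one: there the place was ortho to a large group, whereas here it is ortho to a chloro group and para to a large group. Resting on that earlier step, which stayed within the scatter, compound 4 is expected to give about 12000 nM in this assay, an estimated step of a 1.0-fold lower number from compound 3 to compound 4 (0.00 log units; within the scatter).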

Compound 4, half-maximal inhibitory concentration: 15500 nM
Beside the measured number, compound 4's estimate is 1.3-fold (0.11 log units) below it; the range from low to high includes it.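

In this assay, fluoro in place of chloro gave a 1.3-fold higher number from compound 3 to compound 4 (0.11 log units; within the scatter), while the changes of aryl group on the amide nitrogen gave a 1.1-fold higher number from compound 2 to compound 4 (0.03 log units; within the scatter) and a 1.3-fold higher number from compound 1 to compound 4 (0.10 log units; within the scatter). Set beside the earlier exchange of chloro for fluoro, the new step shows no measurable difference between the two places: the same change on two cores in this assay, a 1.2-fold lower number (0.07 log units; within the scatter) from compound 2 to compound 1 and a 1.3-fold higher number (0.11 log units; within the scatter) from compound 3 to compound 4, 1.5-fold (0.18 log units) apart, within the scatter of two such steps. This shows that the exchange stayed within the scatter in both places, but it does not show a real effect of the change in either, and two steps make no rule for other aryl groups.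

Going by these compounds, it remains open whether a methoxy group, a carboxylic acid or an amine on the aryl ring would take the number beyond the scatter. Also open, on these data alone, is how a longer chain between the shared core and the amide would bear on it.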